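The source may report more compounds than this note shows. Statements on the series, on what has been measured and on what is new or still open speak of the compounds shown alone.

Measured compounds:
compound 1, `CC(C)CCN(C)Cc1cn(C2CCCCC2O)nn1`
compound 2, `CN(Cc1cn(C2CCCCC2OC(=O)COc2ccccc2)nn1)CC1CCCCC1`
compound 3, `CC(C)CCN(C)Cc1cn(C2CCCCC2OC(=O)COc2ccccc2)nn1`

In an assay on nucleic acid for inhibition of Nucleic Acid, read by fluorescence, tested at 100 uM (on this read-out lower numbers stand for less inhibition and higher numbers for more inhibition at the one concentration tested (going by the name of the read-out)), compound 1 gives 42%. In this assay compound 2 gives 37%, and compound 3 gives 59%. Compound 2 and compound 1 lie within the scatter of each other, so no order between them is claimed.

Two changes are covered. The first, (hydrogen in place of (phenoxymethyl)carbonyl on an oxygen on a saturated carbon), gives a step of a number 17 percentage points lower from compound 3 to compound 1 (beyond the scatter). The second concerns the shared core and is cyclohexyl in place of isobutyl on a saturated chain carbon bound to an amine nitrogen, with a step of a number 22 percentage points higher from compound 2 to compound 3 (beyond the scatter).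

Compound 4, `CN(Cc1cn(C2CCCCC2O)nn1)CC1CCCCC1`, is not yet measured. Within the data shown here, it differs from compound 2 by hydrogen in place of (phenoxymethyl)carbonyl on an oxygen on a saturated carbon, which is the same change, at the same kind of place, as the one made from compound 3 to compound 1. On that basis a drop in this assay is expected, of a size comparable to the measured step of a number 17 percentage points lower from compound 3 to compound 1 (beyond the scatter), starting from the value of compound 2, 37%. The expected step is a number 15 percentage points lower from compound 2 to compound 4 (beyond the scatter). This rests on one measured pair only, so the range is kept wide. Compound 4 is estimated at 22%, expected between 8% and 38%.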

Compound 4, a percentage reported as inhibition, at one concentration (the size of the read-out at that concentration, not a potency): 47%
The estimate for compound 4 lay 25 percentage points below the measured number; measured number above the stated range.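

In this assay, hydrogen in place of (phenoxymethyl)carbonyl on an oxygen on a saturated carbon gives a number 10 percentage points higher from compound 2 to compound 4 (within the scatter), which does not reproduce the step seen with isobutyl in the side chain: the same change on two cores in this assay, a number 17 percentage points lower (beyond the scatter) from compound 3 to compound 1 and a number 10 percentage points higher (within the scatter) from compound 2 to compound 4, 27 percentage points apart, beyond the scatter of two such steps. Cyclohexyl in place of isobutyl on a saturated chain carbon bound to an amine nitrogen likewise depends on what sits on the oxygen, with a number 5 percentage points higher from compound 1 to compound 4 (within the scatter) set against the step in the compounds that keep (phenoxymethyl)carbonyl: the same change on two cores in this assay, a number 22 percentage points higher (beyond the scatter) from compound 2 to compound 3 and a number 5 percentage points lower (within the scatter) from compound 4 to compound 1, 27 percentage points apart, beyond the scatter of two such steps. Neither change therefore carries as a fixed step from one core to the other among these four compounds, but each comparison rests on a single pair at one concentration, so this shows no general rule for the series and gives no reason for the mismatch.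

Still open, from the compounds shown here alone, is whether an acetyl or a benzoyl group on that oxygen would behave as (phenoxymethyl)carbonyl does with each side chain. Also open, going by these compounds, is how a longer chain or a benzyl group on the amine nitrogen would fit with these two side chains.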